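The compounds below may be only part of what the source reports. "The series", "measured", "known", "first", "only" and "open" are said of these compounds alone.

Measured so far:
compound 1 `O=C(CSc1nnnn1-c1cccc2ccccc12)N/N=C/c1cccc(Cl)c1`, 240000 nM
compound 2 `COc1cccc(/C=N/NC(=O)CSc2nnnn2-c2cccc3ccccc23)c1OC`, 192000 nM
compound 3 `COc1ccc(/C=N/NC(=O)CSc2nnnn2-c2cccc3ccccc23)cc1OC`, 191000 nM

In an ADME assay on MT4 cells (Homo sapiens) for cytotoxicity, read by MTT assay (on this read-out lower numbers stand for higher toxicity in this test and higher numbers for lower toxicity in this test), compound 1 gives the highest of the three numbers, with the nearest, compound 2, a step of a 1.3-fold lower number from compound 1 to compound 2 (0.10 log units; within the scatter), and compound 3 a step of a 1.3-fold lower number from compound 1 to compound 3 (0.10 log units; within the scatter). Compounds 2 and 3 differ by a 1.0-fold lower number from compound 2 to compound 3 (0.00 log units; within the scatter). All three therefore stand within the scatter of one another. Compound 4 `O=C(CSc1nnnn1-c1cccc2ccccc12)N/N=C/c1ccc(O)cc1` has not yet been tested in this assay. It differs from compound 1 in that (4-hydroxyphenyl in place of 3-chlorophenyl on a carbon with a double bond to nitrogen). Both measured steps from compound 1 also exchange the 3-chlorophenyl group on the same carbon and stay within the scatter, so the expectation for compound 4 is a step of a 1.1-fold lower number from compound 1 to compound 4 (0.06 log units; within the scatter), with an estimated value of 210000 nM, in the range 100000 nM to 420000 nM.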

Compound 4, half-maximal cytotoxic concentration: > 309000 nM
Compound 4 was reported as a limit; the forecaster's own chance of this, stated with the estimate: 15%; middle value at least 1.4-fold (0.16 log units) away from the limit.
By their numbers in this assay, from the lowest: compounds 3, 2 and 1 (each within the scatter of the next). At a limit, above all of these: compound 4.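

Compound 4 is reported only as a limit of the assay: the limit of > 309000 nM in this assay, at which 1 of the 4 values shown sits. On the carbon with a double bond to nitrogen, 4-hydroxyphenyl gives an at least 1.2-fold higher number from compound 1 to compound 4 (0.10 log units; that floor lies within the scatter), an at least 1.6-fold higher number from compound 3 to compound 4 (0.20 log units; that floor lies within the scatter) and an at least 1.6-fold higher number from compound 2 to compound 4 (0.20 log units; that floor lies within the scatter) in this assay. Each floor lies within the scatter, so a hydrogen-bond donor on this group brings no sign of a lower number, though no firm rise is shown either.

Going by these compounds, the true size of these steps stays open. So does whether an amine or a carboxylic acid in place of the hydroxyl would keep the number this high.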